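The compounds below may be only part of what the source reports. "The series", "measured", "known", "first", "only" and "open" are said of these compounds alone.

Measured so far in an in vitro ADME assay on microsomes from liver (Homo sapiens) for metabolic stability; on this read-out lower numbers stand for slow clearance and higher numbers for fast clearance:
compound 1, `CNS(=O)(=O)c1ccc(-c2cnc(N)c(-c3ccc(OC)nc3)c2)cc1`: 9.6 mL.min-1.g-1
compound 2, `COc1ccc(-c2cc(-c3ccc(-n4cccn4)cc3)cnc2N)cn1`: 9 mL.min-1.g-1

Compound 2 stands lowest of the two numbers, and compound 1 is nearest: a 1.1-fold lower number from compound 1 to compound 2 (0.03 log units; within the scatter). Compound 3, `COc1ccc(-c2cc(-c3ccc(C(N)=O)cc3)cnc2N)cn1`, differs from compound 2 in one place: carbamoyl in place of 1H-pyrazol-1-yl on an aromatic carbon. Among the measured compounds shown here, the only measured step bearing on this change is the exchange of one group at the same position, a 1.1-fold lower number from compound 1 to compound 2 (0.03 log units; within the scatter), which lay within the scatter. From that, a step no larger than the scatter is expected for this assay. Compound 3 is therefore estimated at 9 mL.min-1.g-1, in the range 4.5 mL.min-1.g-1 to 18 mL.min-1.g-1, meaning an expected step of no change at the digits printed from compound 2 to compound 3 (within the scatter).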

Compound 3, intrinsic clearance in microsomes: < 7 mL.min-1.g-1
Compound 3 gave a limit, no number (the forecaster's own chance of this, stated with the estimate: 5%); middle value at least 1.2-fold (0.10 log units) from the limit.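

In this assay compound 3 gave < 7 mL.min-1.g-1 as a limit of the assay and not a number. Carbamoyl on this aromatic carbon gives an at least 1.2-fold lower number from compound 2 to compound 3 (0.10 log units; that floor lies within the scatter) and an at least 1.3-fold lower number from compound 1 to compound 3 (0.13 log units; that floor lies within the scatter) so both steps are floors whose true size is unknown. The earlier compounds shown here showed only a step within the scatter at this position, whereas carbamoyl alone reaches the limit here: the limit of < 7 mL.min-1.g-1 in this assay, at which 1 of the 3 values shown sits.

As far as these compounds go, how far under the limit compound 3 lies stays open. So does whether an amine or a carboxylic acid on this aromatic carbon would also reach it.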